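The source may hold more compounds than are shown below. What is called first, only, known or untested is meant among the compounds shown, and "the series" means these compounds.

Compound 1 `O=C(O)c1ccc2c(c1)no[n+]2[O-]` supplies the shared core, which compound 2 `O=C(CCCOC(=O)c1ccc2c(c1)no[n+]2[O-])NO` and compound 3 `O=C(CCCCOC(=O)c1ccc2c(c1)no[n+]2[O-])NO` also carry. In a functional assay on KG-1 cells (Homo sapiens) for inhibition, read by MTT assay, with a stated time of 48 h (a lower number here means a stronger inhibitor, a higher number a weaker inhibitor), compound 1 stands as "not determined" (no result reported) and so offers no number for comparison. Compound 2 gives 4020 nM and compound 3 gives 8190 nM as the higher of the two numbers, which makes it the weaker inhibitor of the pair. Compound 4 `O=C(CCCCCOC(=O)c1ccc2c(c1)no[n+]2[O-])NO` takes the chain one stage further, with (hydroxycarbamoyl)methyl in place of hydroxycarbamoyl on a saturated chain carbon, four bonds along the chain from an oxygen next to a carbonyl group as the counted difference: (hydroxycarbamoyl)methyl in place of hydroxycarbamoyl on a saturated chain carbon, four bonds along the chain from an oxygen next to a carbonyl group. Within the data shown here, only one measured step bears on this, the same replacement three bonds along the chain: a 2.0-fold higher number from compound 2 to compound 3 (0.31 log units; beyond the scatter) is modest in size. A single step sets no trend. In this assay a change no larger than that one is therefore expected, upward if at all, and quite possibly within the scatter. The expected step is a 1.1-fold higher number from compound 3 to compound 4 (0.04 log units; within the scatter) in this estimate. Compound 4 is expected at 9000 nM with an estimated range from 3500 nM to 20000 nM for repeated measurements.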

Compound 4, half-maximal inhibitory concentration: 3690 nM
For compound 4 the middle estimate is 2.4-fold (0.39 log units) above the measured one; the range from low to high includes it.
By their numbers in this assay, from the lowest: compounds 4 and 2 (each within the scatter of the next); then compound 3.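

In this assay the added chain carbon does not act in one direction: the earlier extension gave a 2.0-fold higher number from compound 2 to compound 3 (0.31 log units; beyond the scatter), whereas the next one, the (hydroxycarbamoyl)methyl in place of hydroxycarbamoyl four bonds along the chain from an oxygen next to a carbonyl group, gives a 2.2-fold lower number from compound 3 to compound 4 (0.35 log units; beyond the scatter) and so reverses the sign at a position one bond further out. The longer chain also ends level with the shorter one, with a 1.1-fold lower number from compound 2 to compound 4 (0.04 log units; within the scatter), so across these three compounds there is no steady rise or fall with chain length, and compound 3 alone stands apart from the other two, going against any such trend. Nothing available here accounts for this turn in direction.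

Among these compounds, with only three chain lengths, and with steps that are modest in size, these compounds cannot show whether the turn at compound 4 marks a lasting change or a single irregularity, and a longer chain would be needed to tell. They also leave open how much of the number depends on the hydroxycarbamoyl end itself, which a carboxylic acid at the end of the same chain would test.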